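This account rests on a few compounds, and the source may have more. Where it says the series, first, only, none or still open, it means among the compounds named here.

Of the compounds shown here, three sharing one core have so far been measured in an assay for binding affinity to 5-hydroxytryptamine receptor 1F (Homo sapiens), read by radioligand binding; a lower number here means a stronger inhibitor, a higher number a weaker inhibitor. Compound 1 `CCCCCCCC(=O)Nc1ccc2[nH]cc(C3CCN(C)CC3)c2n1` gives 20 nM. Compound 2 `COc1ccccc1C(=O)Nc1ccc2[nH]cc(C3CCN(C)CC3)c2n1` gives 20 nM, and compound 3 `CN1CCC(c2c[nH]c3ccc(NC(=O)c4cccc(F)c4)nc23)CC1` gives 11 nM. Compound 3 has the lowest of the three numbers, yet the steps of a 1.8-fold lower number from compound 1 to compound 3 (0.26 log units; within the scatter) and a 1.8-fold lower number from compound 2 to compound 3 (0.26 log units; within the scatter) both lie within the scatter, as does no change at the digits printed from compound 1 to compound 2 (within the scatter), so none of the three is set apart from the others. Compound 4 `CN1CCC(c2c[nH]c3ccc(NC(=O)c4ccc(C#N)cc4)nc23)CC1` has not been measured; its difference from compound 3 is 4-cyanophenyl in place of 3-fluorophenyl on a carbonyl carbon. For the measured compounds named here, every exchange made so far on that same carbonyl carbon, from heptyl to 2-methoxyphenyl or to 3-fluorophenyl, left this assay unmoved beyond the scatter, and these are the only steps that bear on the new exchange. The step from 3-fluorophenyl to 4-cyanophenyl is therefore expected to stay within the scatter as well, with no direction favoured. The expected step is a 1.4-fold higher number from compound 3 to compound 4 (0.13 log units; within the scatter). Compound 4 is estimated at 15 nM, with a range from 5 nM to 45 nM.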

Compound 4, inhibition constant: 7.2 nM
The estimate for compound 4 lay 2.1-fold (0.32 log units) above the measured number, and the stated range covers the measured number.
By their numbers in this assay, from the lowest: compounds 4, 3, 1 and 2 (each within the scatter of the next, the first and the last beyond it).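

For the compounds shown here, on the carbonyl carbon of the shared core, 4-cyanophenyl gives the first exchanges to leave the scatter in this assay with a 2.8-fold lower number from compound 2 to compound 4 (0.44 log units; beyond the scatter) and a 2.8-fold lower number from compound 1 to compound 4 (0.44 log units; beyond the scatter) both modest in size, so this position is not wholly indifferent to the group it carries. Against 3-fluorophenyl the exchange stays unresolved, with a 1.5-fold lower number from compound 3 to compound 4 (0.18 log units; within the scatter) leaving the two aryl amides indistinguishable, and only the outer ends of the series separate. Nothing available explains this shift in the number.

Going by these compounds, what 3-cyanophenyl or 4-fluorophenyl would give on this carbonyl carbon stays open, leaving the roles of the nitrile and of its place on the ring unseparated. Also open, on these data alone, is whether a phenyl ring carrying an amine or a carboxylic acid would move the number further in either direction.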